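The compounds below may be only part of what the source reports. "The series", "measured", "known", "first", "only" and "open" are said of these compounds alone.

Measured so far:
compound 1 `CCOC(=O)C(C(=O)c1ccc(OC)cc1)C(NC(C)=O)c1ccc(C(C)C)cc1`, 98.8%
compound 2 `CCOC(=O)C(C(=O)c1ccc(OC)cc1)C(NC(C)=O)c1cc(OC)c(OC)c(OC)c1`, 97.8%

In an ADME assay on Vero cells (Chlorocebus sabaeus) for cytotoxicity, read by MTT assay, tested at 25 uM (on this read-out lower numbers stand for a stronger effect and higher numbers for a weaker effect at the one concentration tested), compound 1 gives 98.8%, the top of the two numbers, and compound 2 gives 97.8%, a gap that lies within the scatter, so the two cannot be told apart. Both sit near the upper end of the scale, a weak effect. Compound 3 `CCOC(=O)C(C(=O)c1ccc(OC)cc1)C(NC(C)=O)c1cc(OC)ccc1Br` is not yet measured. It differs from compound 1 in one place: 2-bromo-5-methoxyphenyl in place of 4-isopropylphenyl on a saturated chain carbon bound to an amide-type nitrogen and a saturated chain carbon. For the measured compounds named here, no measured pair covers this exchange. The step of a number 3.8 percentage points lower from compound 1 to compound 3 (within the scatter) is expected to stay within the scatter, in no clear direction. Compound 3 is estimated at 95%, between 84% and 100%.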

Compound 3, a percentage reported as activity, at one concentration (the size of the read-out at that concentration, not a potency): 96.3%
Beside the measured number, compound 3's estimate is 1.3 percentage points below it; the range from low to high includes it.
By their numbers in this assay, from the lowest: compounds 3, 2 and 1 (each within the scatter of the next).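

In this assay the exchange of 4-isopropylphenyl for 2-bromo-5-methoxyphenyl gives a number 2.5 percentage points lower from compound 1 to compound 3 (within the scatter). This position on a saturated chain carbon bound to an amide-type nitrogen and a saturated chain carbon therefore takes a bromine and a hydrogen-bond acceptor with no step beyond the scatter, the only single-place exchange shown in the series. No measurement shown offers an explanation for this result. As far as these compounds go, it remains open whether an amine or a carboxylic acid in place of these groups would give a step beyond the scatter.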